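Sulfonyl hydrazides: trifluoromethyl on the anilino ring

The source may hold more compounds than are shown below. What is called first, only, known or untested is meant among the compounds shown, and "the series" means these compounds.

Measured so far:
compound 1, `Cc1cccc(NNS(=O)(=O)c2ccc(S(C)(=O)=O)cc2)c1`, gives 7850 nM
compound 2, `CC(=O)Nc1ccc(S(=O)(=O)NNc2ccccc2)cc1`, gives > 10000 nM

Of the compounds shown here, two have been measured in an assay on HeLa cells for inhibition of Indoleamine 2,3-dioxygenase 1 (Homo sapiens), read by spectrophotometry, with a stated time of 24 h; a higher number here means that more compound is needed for the effect, a lower number that less compound is needed. Compound 1 sits at 7850 nM, a number rather than a limit. For the measured compounds named here, for compound 2 the reading is only a limit of the assay, > 10000 nM; it is the case noted in the limit of > 10000 nM in this assay, at which 1 of the 2 values shown sits, so no number is known for compound 2, and no step between the two measured compounds can be drawn from them.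

The next compound, compound 3, `CC(=O)Nc1ccc(S(=O)(=O)NNc2ccc(C(F)(F)F)cc2)cc1`, differs from compound 2 in one place: trifluoromethyl in place of hydrogen on an aromatic carbon. The trifluoromethyl group enters on an aromatic carbon of a six-membered aromatic ring of carbon only, without changing the acetamido-bearing sulfonyl half.

Going by the values given here, with no measured step behind it, the size of the change in this assay is open. The step from compound 2 to compound 3 is expected to be an at least 1.2-fold lower number from compound 2 to compound 3 (0.09 log units; that floor lies within the scatter), a modest move toward a lower number, though it may well stay within the scatter. Compound 3 is estimated at 8000 nM, between 2000 nM and 30000 nM, with a real chance that the assay again reports only a limit.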

Compound 3, half-maximal effective concentration: 181 nM
Compound 3: middle estimate off by 44-fold (1.65 log units), on the high side, outside the stated range (below it).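

In this assay compound 2 gives > 10000 nM, which is a limit of the assay and not a number: the limit of > 10000 nM in this assay, at which 1 of the 3 values shown sits. Trifluoromethyl in place of hydrogen on an aromatic carbon, para to a large group, gives an at least 55-fold lower number from compound 2 to compound 3 (1.74 log units; beyond the scatter), so the printed size is a floor and the full size of the step stays unknown. For the compounds shown here, this is the first reading of a single change on the anilino ring, and it shows that this carbon responds strongly to substitution while the acetamido-bearing sulfonyl half stays the same.

One step cannot show whether the drop in the number belongs to trifluoromethyl itself, or whether a chlorine atom, a nitrile, a methoxy group or an amine on the same carbon would do the same. Also open, from the compounds shown here alone, are how trifluoromethyl behaves on another carbon of that ring and whether it has a similar effect in compound 1, which carries a methylsulfonyl group and differs from compound 3 in more than one place.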